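A few compounds are considered here, and "the series" means these few. Any claim that something is new, unique, unknown or untested is made for them only; others in the source may bear on it.

Working notes on the series, read in a functional assay on KB cells (Homo sapiens) for antiproliferative activity, read by sulforhodamine B assay, with a stated time of 3 days; a lower number here means that less compound is needed, a higher number that more compound is needed for the effect. Going by the values given here, compound 1 (`CCC1=C(O)c2c(oc(-c3ccc(C(C)C)cc3)cc2=O)C(CC)(CC)C1=O`) gives 8.13 uM, and compound 2 (`CCC1=C(O)c2c(oc(-c3ccc(C)c(Cl)c3)cc2=O)C(CC)(CC)C1=O`) gives 39 uM, the higher of the two numbers so far. The unmeasured compound 3 (`CCC1=C(O)c2c(oc(-c3ccc(O)c(O)c3)cc2=O)C(CC)(CC)C1=O`) carries 3,4-dihydroxyphenyl in place of 3-chloro-4-methylphenyl on an aromatic carbon next to the ring oxygen: 3,4-dihydroxyphenyl in place of 3-chloro-4-methylphenyl on an aromatic carbon. Among the compounds with values here, one measured step bears on this change: a 4.8-fold higher number from compound 1 to compound 2 (0.68 log units; beyond the scatter), a modest step beyond the scatter at the same place. Within the data shown here, it shows that the number in this assay can move with the aryl group, but no measured compound carries a hydroxyl on that ring, so the direction remains open. No step beyond the scatter is therefore expected as the central case, although a modest step either way remains possible. The estimated step is a 1.3-fold lower number from compound 2 to compound 3 (0.11 log units; within the scatter). For compound 3 the expected value is 30 uM, with an estimated range of 8 uM to 100 uM.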

Compound 3, concentration for half-maximal effect: 10 uM
Estimate against measurement, compound 3: 3.0-fold (0.48 log units) above, within the range that was stated.
By their numbers in this assay, from the lowest: compounds 1 and 3 (each within the scatter of the next); then compound 2.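

At this position in this assay, the change to 3,4-dihydroxyphenyl gives a 3.9-fold lower number from compound 2 to compound 3 (0.59 log units; beyond the scatter) and shows that hydroxyl groups on this aryl ring are compatible with a number lower than that of compound 2. Replacing 4-isopropylphenyl with the same group gives a 1.2-fold higher number from compound 1 to compound 3 (0.09 log units; within the scatter) and so shows that two aryl groups with no substituent in common can give numbers within the scatter of each other, leaving compound 2 alone apart among the three. No evidence available here accounts for either step.

The compounds shown leave open whether a single hydroxyl on this ring would give a number like that of compound 3, and whether methoxy or amino groups could take the place of the two hydroxyls. They also leave open whether the chlorine or the methyl of compound 2 sets its higher number.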